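Acid Turned Amide on a Chain

A few compounds are considered here, and "the series" means these few. Any claim that something is new, unique, unknown or untested is made for them only; others in the source may bear on it.

Compound 1 `Cc1nc(-c2ccc(C(F)(F)F)cc2)sc1CNc1ccc(C(=O)O)cc1`: < 10000 nM (a limit, not a number)
Compound 2 `O=C(O)CCCc1ccc(NCc2cccc(Oc3ccccc3)c2)cc1`: 1120 nM
Compound 3 `Cc1nc(-c2ccc(C(F)(F)F)cc2)sc1CNc1ccc(CCC(N)=O)cc1`: 12.9 nM

In a functional assay on CHO cells for agonist activity at Free fatty acid receptor 1 (Homo sapiens) (on this read-out lower numbers stand for an effect already at smaller amounts and higher numbers for an effect only at larger amounts of compound), compound 1 reaches only a limit, < 10000 nM. Compound 2 gives 1120 nM, the highest of the two numbers shown, and compound 3 gives 12.9 nM. The step that the limit leaves unreadable from compound 1 to compound 3 cannot be sized, as the starting point is the limit (the limit of < 10000 nM in this assay, at which 1 of the 3 values shown sits); it points downward at most. Compound 4 `CC(C)NC(=O)CCc1ccc(NCc2cccc(Oc3ccccc3)c2)cc1` differs from compound 2 by isopropylcarbamoyl in place of carboxymethyl on a saturated chain carbon, two bonds along the chain from an aromatic carbon. This is again an acid turned into an amide, so a lower number is expected, though its size rests on one unreadable step. The expected step is a 5.6-fold lower number from compound 2 to compound 4 (0.75 log units; beyond the scatter). Compound 4 is estimated at 200 nM, between 40 nM and 1500 nM.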

Compound 4, half-maximal effective concentration: 39.8 nM
For compound 4 the middle estimate is 5.0-fold (0.70 log units) above the measured one; measured number below the stated range.
By their numbers in this assay, from the lowest: compound 3; then compound 4; then compound 2.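

The earlier step from an acid to an amide cannot be read, but on this chain the change has a size: a 28-fold lower number from compound 2 to compound 4 (1.45 log units; beyond the scatter). In this assay, a carboxylic acid on the chain is therefore not needed for a low number in the core of compound 2. No measurement shown explains why the amide gives the lower number. Whether the amide alone accounts for the step, or the isopropyl group also contributes, remains open. A methyl amide or an amine on the same chain would help separate the two.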